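Nitrofuran carboxamides on Vero cells: compound 3 to compound 4

This account rests on a few compounds, and the source may have more. Where it says the series, first, only, none or still open, it means among the compounds named here.

The compounds measured so far:
- compound 1, `O=C(Nc1nc(-c2cccc(Br)c2)cs1)c1ccc([N+](=O)[O-])o1`, 71000 nM
- compound 2, `O=C(Nc1nc(-c2cccc(C(F)(F)F)c2)cs1)c1ccc([N+](=O)[O-])o1`, 23900 nM
- compound 3, `CC(C)(C)OC(=O)Nc1cccc(-c2csc(NC(=O)c3ccc([N+](=O)[O-])o3)n2)c1`, "not determined" (no result reported)

In an ADME assay on Vero cells (Chlorocebus sabaeus) for cytotoxicity, read by MTT assay, with a stated time of 72 h (a lower number here means a stronger inhibitor, a higher number a weaker inhibitor), compound 1 gives 71000 nM and compound 2 gives 23900 nM. Going by the values given here, the one step between them, a 3.0-fold lower number from compound 1 to compound 2 (0.47 log units; beyond the scatter), is the only measured step in this set. Compound 3 stands without a number in this assay; no result was reported for it. Compound 4, `CS(=O)(=O)Nc1cccc(-c2csc(NC(=O)c3ccc([N+](=O)[O-])o3)n2)c1`, differs from compound 3 by methylsulfonyl in place of tert-butoxycarbonyl on a nitrogen on an aromatic ring. Among the compounds with values here, no measured step touches the (tert-butoxycarbonyl)amino group or the methanesulfonamido group, so nothing bears directly on this change; the only step known, from compound 1 to compound 2, shows that exchanging one group on that aromatic carbon moved this assay by a modest amount, and no larger movement is seen anywhere in the set. Compound 4 is therefore expected to fall within the span covered by compound 1 and compound 2. The estimate for compound 4 in this assay is 40000 nM, with a range from 15000 nM to 110000 nM.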

Compound 4, half-maximal inhibitory concentration: < 2820 nM
Compound 4: only a limit was reported; the forecaster's own chance of this, stated with the estimate: 30%; at least 14-fold (1.15 log units) between middle value and limit.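

In this assay compound 4 carries a limit of the assay and not a number: the limit of < 2820 nM in this assay, at which 1 of the 4 values shown sits. Even so, methanesulfonamido on this aromatic carbon gives an at least 8.4-fold lower number from compound 2 to compound 4 (0.92 log units; beyond the scatter) and an at least 25-fold lower number from compound 1 to compound 4 (1.40 log units; beyond the scatter). Going by these compounds alone, both steps are larger than a 3.0-fold lower number from compound 1 to compound 2 (0.47 log units; beyond the scatter), the only step available before, so a change of group at this place can move the read-out further than the earlier compounds showed.

Compound 3 has no number, so the step from it to compound 4 cannot be read, and the exchange of (tert-butoxycarbonyl)amino for methanesulfonamido remains unsized. On these data alone, it also remains open how far the true value of compound 4 lies from its limit, and whether a free amine or a carboxylic acid at this place would shift the read-out in the same way.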